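The source may hold more compounds than are shown below. What is called first, only, known or untested is meant among the compounds shown, and "the series" means these compounds.

Working notes on the series. Compound 1 `CN1CCN(CCCCCCn2c3c(c4ccccc42)C(=O)c2c[n+]([O-])c4ccccc4c2C3=O)CC1` gives 330 nM in a functional assay on A549 cells (Homo sapiens) for cytotoxicity, read by MTT assay, with a stated time of 72 h; a lower number here means a stronger inhibitor, a higher number a weaker inhibitor. Compound 2 `O=C1c2c[n+]([O-])c3ccccc3c2C(=O)c2c1c1ccccc1n2Cc1cn(C[C@@H](O)CO)nn1` gives 390 nM in this assay, and the step of a 1.2-fold higher number from compound 1 to compound 2 (0.07 log units; within the scatter) shows that exchanging the basic chain for the diol-bearing triazolylmethyl group changes little. Compound 3 `CC1(C)OCC(Cn2cc(Cn3c4c(c5ccccc53)C(=O)c3c[n+]([O-])c5ccccc5c3C4=O)nn2)O1` gives 80 nM in this assay, the strongest inhibitor of the three measured compounds, and the step of a 4.9-fold lower number from compound 2 to compound 3 (0.69 log units; beyond the scatter) is the only one beyond the scatter so far.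

Compound 4 `O=C1c2c[n+]([O-])c3ccccc3c2C(=O)c2c1c1ccccc1n2Cc1cn([C@H]2O[C@H](CO)[C@@H](O)[C@H]2O)nn1` is not yet measured. Change: 3,4-dihydroxy-5-(hydroxymethyl)oxolan-2-yl in place of (2,2-dimethyl-1,3-dioxolan-4-yl)methyl on an aromatic nitrogen. For the measured compounds named here, the group that enters carries free hydroxyls, as did the group that left in the step of a 4.9-fold lower number from compound 2 to compound 3 (0.69 log units; beyond the scatter), so the one step that bears on this change ran in the direction of fewer free hydroxyls giving a lower number. Compound 4 is therefore expected to move back toward compound 2, with a step of a 3.8-fold higher number from compound 3 to compound 4 (0.57 log units; beyond the scatter) of modest size in this assay. The estimate for compound 4 is 300 nM, with a range from 120 nM to 800 nM.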

Compound 4, half-maximal inhibitory concentration: 2680 nM
Estimate against measurement, compound 4: 8.9-fold (0.95 log units) below, outside the stated range (above it).
By their numbers in this assay, from the lowest: compound 3; then compounds 1 and 2 (each within the scatter of the next); then compound 4.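

For the compounds shown here, on the aromatic nitrogen of the five-membered aromatic ring with 3 nitrogen, the entry of 3,4-dihydroxy-5-(hydroxymethyl)oxolan-2-yl for (2,2-dimethyl-1,3-dioxolan-4-yl)methyl gives, in this assay, a 34-fold higher number from compound 3 to compound 4 (1.53 log units; beyond the scatter), the largest step so far. The presence of free hydroxyls does not alone set the number at this position: replacing 2,3-dihydroxypropyl, which also carries them, with the same oxolane group still gives a 6.9-fold higher number from compound 2 to compound 4 (0.84 log units; beyond the scatter). Nothing measured here bears on the cause of either step.

As far as these compounds go, it remains open whether the rise follows the oxolane ring or its hydroxyl groups; an unsubstituted oxolan-2-yl or a trimethoxy-substituted oxolane on the same nitrogen would separate the two. Also open, from the compounds shown here alone, is how an amine, such as a 2-(dimethylamino)ethyl group, would read at this nitrogen.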